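Cyclopropane diamide series: anilide change from compound 2

The source may hold more compounds than are shown below. What is called first, only, known or untested is meant among the compounds shown, and "the series" means these compounds.

Measured so far:
compound 1 `CN(C)C(=O)c1cc2cnc(Nc3ccc(NC(=O)C4(C(=O)Nc5ccc(F)cc5)CC4)cc3F)nc2n1C1CCCC1` — 44.4%
compound 2 `CN(C)C(=O)c1cc2cnc(Nc3ccc(NC(=O)C4(C(=O)Nc5ccc(Cl)c(C(F)(F)F)c5)CC4)cc3)nc2n1C1CCCC1` — 61.1%

Two compounds have numbers in a functional assay on SiHa cells (Homo sapiens) for inhibition, read by CCK-8 assay, with a stated time of 72 h, tested at 10 uM; on this read-out higher numbers stand for more inhibition of growth at the one concentration tested and lower numbers for less inhibition of growth. Compound 1 gives 44.4%. Compound 2 gives 61.1%, the higher of the two numbers, and its gap to compound 1 lies beyond the scatter. Among the compounds with values here, compounds 1 and 2 differ in more than one place, so no single step between them can be read.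

Compound 3 `CN(C)C(=O)c1cc2cnc(Nc3ccc(NC(=O)C4(C(=O)Nc5ccc(O)cc5)CC4)cc3)nc2n1C1CCCC1` is not yet measured. It differs from compound 2 in one place: 4-hydroxyphenyl in place of 4-chloro-3-(trifluoromethyl)phenyl on an amide-type nitrogen. Within the data shown here, no measured pair isolates this change, so the expectation rests on compound 2 alone, which stands at 61.1% in this assay. A downward step is expected from that value, a number 16.1 percentage points lower from compound 2 to compound 3 (beyond the scatter), though the range kept around it is wide and a result within the scatter of compound 2 is not ruled out. Compound 3 is estimated at 45%, between 25% and 65%.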

Compound 3, percent growth inhibition at one concentration: 94.3%
For compound 3 the middle estimate is 49.3 percentage points below the measured one; measured number above the stated range.
By their numbers in this assay, from the lowest: compound 1; then compound 2; then compound 3.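

In this assay, the aryl group on the amide-type nitrogen emerges as a position where a single change has a large effect: 4-hydroxyphenyl in place of 4-chloro-3-(trifluoromethyl)phenyl gives a number 33.2 percentage points higher from compound 2 to compound 3 (beyond the scatter). The chlorine and trifluoromethyl groups of compound 2 are therefore not required for growth inhibition at this concentration, and compound 3, which carries neither, reaches 94.3%. Nothing available bears on the reason for this step.

The compounds shown leave open whether the gain depends on the hydroxyl group or on the loss of the two substituents of compound 2; 4-methoxyphenyl and unsubstituted phenyl on the same nitrogen would separate these readings. A comparison of compound 1 with the others cannot be read, as it differs from them in more than one place.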